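The compounds below may be only part of what the source reports. "The series", "measured", "known", "first", "only" and "open" are said of these compounds alone.

Compound 1 `COc1ccc(Cn2nnc(O)c2C(=O)Nc2cccc(C(F)(F)F)c2)cc1`: 81400 nM
Compound 2 `COc1ccc(Cn2nnc(O)c2C(=O)Nc2ccc(-c3ccccc3)cc2)cc1`: 57900 nM
Compound 3 `COc1ccc(Cn2nnc(O)c2C(=O)Nc2cccc(-c3ccccc3)c2)cc1`: 52100 nM

These values come from a functional assay on CWR22R cells (Homo sapiens) for inhibition, read by sulforhodamine B assay, with a stated time of 72 h; a higher number here means a weaker inhibitor, a lower number a stronger inhibitor. Compound 1 lies within the scatter of both compound 2 and compound 3, so the three cannot be ranked. Compound 4 `COc1ccc(Cn2nnc(O)c2C(=O)Nc2cccc(-c3ccc(O)cc3)c2)cc1` has 4-hydroxyphenyl in place of trifluoromethyl on an aromatic carbon of compound 1: 4-hydroxyphenyl in place of trifluoromethyl on an aromatic carbon. The closest measured change puts phenyl at that same place, and it gave a 1.6-fold lower number from compound 1 to compound 3 (0.19 log units; within the scatter). Within the data shown here, no measured compound carries 4-hydroxyphenyl, so that small step is the only guide, and no shift beyond the scatter is expected in this assay. The estimated step is a 1.7-fold lower number from compound 1 to compound 4 (0.23 log units; within the scatter). For compound 4 the expected value is 48000 nM, with an estimated range of 20000 nM to 100000 nM.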

Compound 4, half-maximal inhibitory concentration: 67500 nM
For compound 4 the middle estimate is 1.4-fold (0.15 log units) below the measured one; measured number inside the range.
By their numbers in this assay, from the lowest: compounds 3, 2, 4 and 1 (each within the scatter of the next).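

In this assay, putting 4-hydroxyphenyl in place of trifluoromethyl gives a 1.2-fold lower number from compound 1 to compound 4 (0.08 log units; within the scatter) and adding only a hydroxy to the phenyl ring gives a 1.3-fold higher number from compound 3 to compound 4 (0.11 log units; within the scatter). Both steps lie within the scatter, so a hydroxy on the added ring, new in this series, does not set this compound apart at this position. Nothing on hand explains this result. Still open, on these data alone, is whether an amine or a carboxylic acid on that ring, or a longer chain at the same place, would move the number beyond the scatter.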